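Serum half-life across carbamate, carbonate and ester linkers

A few compounds are considered here, and "the series" means these few. Any claim that something is new, unique, unknown or untested is made for them only; others in the source may bear on it.

Measured so far:
compound 1 `Cc1cn(C2CC(N=[N+]=[N-])C(COC(=O)NCCCO)O2)c(=O)[nH]c1=O` — > 48 h
compound 2 `Cc1cn(C2CC(N=[N+]=[N-])C(COC(=O)OCCCCO)O2)c(=O)[nH]c1=O` — 0.5 h
compound 3 `Cc1cn(C2CC(N=[N+]=[N-])C(COC(=O)NCCCN)O2)c(=O)[nH]c1=O` — > 48 h

In an ADME assay on the whole organism (serum) with Homo sapiens as the target (a higher number here means that the compound lasts longer, a lower number that the compound disappears faster), compound 1 gives > 48 h, a limit of the assay rather than a number. Compound 3 in this assay also stands at > 48 h, again a limit. Compound 2, by contrast, gives 0.5 h in this assay. The measured steps read an at least 96-fold lower number from compound 1 to compound 2 (1.98 log units; beyond the scatter) and an at least 96-fold higher number from compound 2 to compound 3 (1.98 log units; beyond the scatter), while the step that the two limits leave unreadable from compound 1 to compound 3 cannot be sized because of the limit of > 48 h in this assay, at which 2 of the 3 values shown sit.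

Compound 4 `Cc1cn(C2CC(N=[N+]=[N-])C(COC(=O)CCCN)O2)c(=O)[nH]c1=O` is not yet measured. It differs from compound 3 by 3-aminopropyl in place of (3-aminopropyl)amino on a carbonyl carbon. This again touches the carbonyl carbon that carries the carbamate nitrogen in compound 3, the same place where the carbamate-to-carbonate exchanges between compound 1, compound 2 and compound 3 moved this assay by large amounts in both directions. Compound 3 sits at the upper limit, so only a drop can be read. The expectation is that compound 4 leaves the limit and falls, with a step estimated at an at least 32-fold lower number from compound 3 to compound 4 (1.50 log units; beyond the scatter). Compound 4 is therefore expected at 1.5 h in this assay, in the range 0.3 h to 8 h.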

Compound 4, half-life: 0.433 h
Compound 4: middle estimate off by 3.5-fold (0.54 log units), on the high side; the measured number falls inside the stated range.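

In this assay, the exchange of (3-aminopropyl)amino for 3-aminopropyl on the carbonyl carbon gives an at least 110-fold lower number from compound 3 to compound 4 (2.04 log units; beyond the scatter) while the terminal amine and the three-carbon chain stay in place, so the loss of the carbamate nitrogen alone is enough to turn a carbamate at the limit into a short-lived ester, and the terminal amine does not keep the half-life long by itself. Set against the carbonate, the ester gives a 1.2-fold lower number from compound 2 to compound 4 (0.06 log units; within the scatter) even though linker and chain both differ, so within these compounds the carbamates stand apart and ester and carbonate cannot be told apart. The comparison with the hydroxy carbamate gives an at least 110-fold lower number from compound 1 to compound 4 (2.04 log units; beyond the scatter) and tells the same story, though this step and the one from compound 3 are only lower bounds on the true size: the limit of > 48 h in this assay, at which 2 of the 4 values shown sit.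

Still open, on these data alone, is whether a methyl group on the carbamate nitrogen would keep a half-life at the limit as the hydrogen-bearing carbamates do. As far as these compounds go, it is equally open whether a longer chain or a terminal carboxylic acid on the ester would shift the half-life away from the level of compound 4 and compound 2.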